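The source may hold more compounds than are shown below. What is called first, only, known or untested is meant among the compounds shown, and "the series" means these compounds.

Measured so far:
compound 1 `CCCCc1cnc(C(CC)Cc2ccc(-c3ccccc3C(=O)O)cc2)[nH]1` — 2720 nM
compound 2 `O=C(O)c1ccccc1-c1ccc(CCc2ncc(CC3CCCCC3)[nH]2)cc1` — 41 nM
compound 3 `CCCCc1cnc(C(Cc2ccc(-c3ccccc3C(=O)O)cc2)C(C)C)[nH]1` — 4620 nM

In an in vitro functional assay on cells for agonist activity at Bombesin receptor subtype-3 (Homo sapiens), read by luminescence and calcium flux (on this read-out lower numbers stand for an effect already at smaller amounts and higher numbers for an effect only at larger amounts of compound), compound 2 gives the lowest of the three numbers; compound 1 stands far above it, and compound 3 further still, both beyond the scatter. Among the measured compounds shown here, the only step between measured compounds that differ in one place is a 1.7-fold higher number from compound 1 to compound 3 (0.23 log units; within the scatter), which concerns a methyl branch on the linker and not the group varied here. Compound 4 `Cc1ccccc1Cc1cnc(CCc2ccc(-c3ccccc3C(=O)O)cc2)[nH]1` is derived from compound 2 by 2-methylphenyl in place of cyclohexyl on a saturated chain carbon bound to an aromatic carbon. For the measured compounds named here, compounds 1 and 3 differ from compound 2 in more than one place, so no single step from them bears on this exchange, and no measured pair swaps a saturated ring for an aromatic ring at this position. The direction of the step is therefore open; the expectation is a moderate rise in the number for compound 4, a 3.7-fold higher number from compound 2 to compound 4 (0.56 log units; beyond the scatter), held with wide uncertainty. Compound 4 is estimated at 150 nM, with a range from 30 nM to 800 nM.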

Compound 4, half-maximal effective concentration: 127 nM
Compound 4: middle estimate off by 1.2-fold (0.07 log units), on the high side, and the stated range covers the measured number.
By their numbers in this assay, from the lowest: compound 2; then compound 4; then compounds 1 and 3 (each within the scatter of the next).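

In this assay, among the compounds shown here, the first single-place reading at this position is a 3.1-fold higher number from compound 2 to compound 4 (0.49 log units; beyond the scatter), for 2-methylphenyl in place of cyclohexyl on a saturated chain carbon bound to an aromatic carbon. A six-membered aromatic ring bearing a methyl group can therefore take the place of the saturated ring at a modest, though real, cost in the number, but this one step changes ring type and adds a methyl group together, so it does not separate the two. No measurement available here accounts for the size of this step.

Still open, from the compounds shown here alone, is how much of the step belongs to the aromatic ring and how much to the methyl group, which a plain phenyl at this place would separate. Also open, going by these compounds, is how a ring carrying an amine, or a longer chain in place of the ring, would read here.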